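A Mirror Image Set Against a Limit

This account rests on a few compounds, and the source may have more. Where it says the series, first, only, none or still open, it means among the compounds named here.

In a functional assay on MCF7 cells (Homo sapiens) for antiproliferative activity, read by luminescence and CellTiter-Glo, with a stated time of 48 h (a higher number here means a weaker inhibitor, a lower number a stronger inhibitor), compound 1 `O=C1CCC[C@@H]([C@H]2C[C@@H]2c2ccccc2)O1` gives > 100000 nM as a limit of the assay, not a number. Compound 2 `C[C@H](Cc1ccccc1)[C@H]1CCCC(=O)O1` likewise gives > 100000 nM as a limit. Compound 1 thus stands at the limit of > 100000 nM in this assay, at which 2 of the 2 values shown sit, and offers no exact number to start from. Compound 3 `O=C1CCC[C@H]([C@@H]2C[C@H]2c2ccccc2)O1` is its mirror image, and the two compounds have the same atoms and bonds and differ only in configuration as drawn: 3 of 3 stereo elements differ (all stereocentres are inverted: mirror images); a stereocentre at a saturated ring carbon is drawn S in compound 1 and R in compound 3; a stereocentre at a saturated ring carbon is drawn S in compound 1 and R in compound 3; a stereocentre at a saturated ring carbon is drawn S in compound 1 and R in compound 3 is the whole change. Within the data shown here, no measured step offers a guide, so in this assay no shift beyond the usual scatter is expected, and another limit is the likeliest report. Compound 3 is expected at 100000 nM with a range of 30000 nM to 300000 nM as the estimate.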

Compound 3, half-maximal inhibitory concentration: > 100000 nM
Compound 3: a limit, no number; the forecaster's own chance of this, stated with the estimate: 85%; the middle value sits exactly at the limit.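

Among these compounds, compound 1 and compound 3 each report only a limit, so no step between these mirror images can be read. The compounds shown leave open whether configuration changes activity at all, as none gives an exact number.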